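Permeability Across Dog Kidney Cells: From Compound 2 to Compound 4

This account rests on a few compounds, and the source may have more. Where it says the series, first, only, none or still open, it means among the compounds named here.

Measured so far:
Compound 1 `CC(C)/C(=C1\C(=O)NC(=O)N1C)c1ccc(-c2ccc3cccc(F)c3c2)[nH]c1=O` gives 6.85 10^-6 cm/s in an ADME assay on MDCK cells (Canis lupus familiaris) for permeability, in the apical to basolateral direction; a lower number here means that the compound crosses the layer more slowly, a higher number that the compound crosses the layer faster.
Compound 2 `CC(C)C(c1ccc(-c2ccc3cccc(F)c3c2)[nH]c1=O)C1C(=O)NC(=O)N1C` is recorded as "not determined" (no result reported) in this assay.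
Compound 3 `CC(C)[C@H](C[C@@H]1OC(=O)NC1=O)c1ccc(-c2ccc3cccc(F)c3c2)[nH]c1=O` gives 10.8 10^-6 cm/s in this assay.

Compound 2 thus stands nowhere on the numbers: no result was reported for it. Its two measured relatives, compound 1 and compound 3, give values that lie within the usual scatter of each other. Compound 4 `CC(C)C(CC1NC(=O)NC1=O)c1ccc(-c2ccc3cccc(F)c3c2)[nH]c1=O` differs from compound 2 as follows: (2,5-dioxoimidazolidin-4-yl)methyl in place of 3-methyl-2,5-dioxoimidazolidin-4-yl on a saturated chain carbon bound to an aromatic carbon and a saturated chain carbon. Among the compounds with values here, no measured step covers this change, so its size in this assay is open. Compound 4 is expected to cross the layer somewhat more slowly than compound 1 and compound 3, with an estimate of 3.5 10^-6 cm/s and a range from 1.2 10^-6 cm/s to 9 10^-6 cm/s.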

Compound 4, apparent permeability: 17.1 10^-6 cm/s
Compound 4: the middle estimate sits 4.9-fold (0.69 log units) below what was measured; the measured number lies above the stated range.
By their numbers in this assay, from the lowest: compounds 1, 3 and 4 (each within the scatter of the next, the first and the last beyond it).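

No step can be read for compound 4, as compound 2 has no number in this assay to compare with it. What swapping 3-methyl-2,5-dioxoimidazolidin-4-yl for (2,5-dioxoimidazolidin-4-yl)methyl does in this assay stays open, and nothing shown here explains the value of compound 4.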